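A few compounds are considered here, and "the series" means these few. Any claim that something is new, unique, unknown or untested is made for them only; others in the source may bear on it.

Among the measured compounds shown here, compound 1 `Nc1ncnn2c([C@@H]3O[C@H](CO)[C@@H](O)[C@H]3O)cc(Br)c12` gives 2000 nM in an ADME assay on cells (Macrophage, Mus musculus) for cytotoxicity (a lower number here means that less compound is tolerated, a higher number that more compound is tolerated), the lowest number of the two measured so far. Compound 2 `Nc1ncnn2c([C@@H]3O[C@H](CO)[C@@H](O)[C@H]3O)cnc12` gives 32000 nM in this assay, a higher number, and the gap between compound 1 and compound 2 lies beyond the scatter. Compound 3 `Nc1ncnn2c([C@@H]3O[C@H](CO)[C@@H](O)[C@H]3O)cc(-c3ccc(Cl)cc3)c12` is the next compound; it differs from compound 1 in one place: 4-chlorophenyl in place of bromo on an aromatic carbon. For the measured compounds named here, no measured pair shows this change, so its effect cannot be read from earlier numbers. The step of a 2.0-fold lower number from compound 1 to compound 3 (0.30 log units; within the scatter) in this assay is expected to run toward a lower number, of moderate size and not certainly beyond the scatter. In this assay compound 3 is expected at 1000 nM, with a range from 300 nM to 6000 nM.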

Compound 3, half-maximal cytotoxic concentration: 5000 nM
The estimate for compound 3 lay 5.0-fold (0.70 log units) below the measured number; the range from low to high includes it.
By their numbers in this assay, from the lowest: compound 1; then compound 3; then compound 2.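

At this aromatic carbon, 4-chlorophenyl in place of bromo gives a 2.5-fold higher number from compound 1 to compound 3 (0.40 log units; beyond the scatter) in this assay. The larger group, with its six-membered aromatic ring of carbon only, therefore does not bring a lower number than bromo at this position, and the modest step runs against the expected direction. No measurement on these compounds bears on the cause of this step.

From the compounds shown here alone, whether the step follows the ring or the chlorine stays open, as an unsubstituted phenyl would separate the two. Going by these compounds, how an amine or a carboxylic acid at this carbon would read also remains unknown.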